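From bromo to cyano in a cytotoxicity series

The compounds below may be only part of what the source reports. "The series", "measured", "known", "first", "only" and "open" are said of these compounds alone.

In an ADME assay on MDBK cells (Bos taurus) for cytotoxicity (a lower number here means that less compound is tolerated, a higher number that more compound is tolerated), compound 1 `Clc1ccccc1Cn1ccc2nc(-c3ccccc3)nc-2c1` reaches a limit of the assay, > 100000 nM. Compound 2 `Brc1ccccc1Cn1ccc2nc(-c3ccccc3)nc-2c1` also reaches a limit, > 100000 nM. Among the measured compounds shown here, compound 3 `Brc1cccc(Cn2ccc3nc(-c4ccccc4)nc-3c2)c1` gives 85000 nM, the only actual number among the three.

The next compound, compound 4 `N#Cc1cccc(Cn2ccc3nc(-c4ccccc4)nc-3c2)c1`, has cyano in place of bromo on an aromatic carbon, meta to a large group: cyano in place of bromo on an aromatic carbon. For the measured compounds named here, no measured step makes this exchange. The closest one, with bromo in place of chloro, is a step that the two limits leave unreadable from compound 1 to compound 2. The two steps that reach the 3-bromophenyl group are an at least 1.1-fold lower number from compound 1 to compound 3 (0.07 log units; that floor lies within the scatter) and an at least 1.1-fold lower number from compound 2 to compound 3 (0.07 log units; that floor lies within the scatter). Neither shows a change beyond the scatter, so these data give no reason to predict a real shift. In this assay, the expected change is a 1.1-fold higher number from compound 3 to compound 4 (0.02 log units; within the scatter), meaning no step beyond the scatter in either direction. Compound 4 is estimated at 90000 nM. Its expected range runs from 45000 nM to 170000 nM.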

Compound 4, half-maximal cytotoxic concentration: > 100000 nM
Compound 4 gave a limit, no number; the forecaster's own chance of this, stated with the estimate: 45%; middle value at least 1.1-fold (0.04 log units) from the limit.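

In this assay, among the compounds shown here, the exchange of bromo for cyano on the aromatic carbon is the first change at this position that can be set against an actual number, and it gives an at least 1.1-fold higher number from compound 3 to compound 4 (0.07 log units; that floor lies within the scatter). So a nitrile can stand in this place without any step beyond the scatter being shown, though the true size of the step stays hidden behind the limit reached by compound 4. The steps from compound 1 and from compound 2 to compound 4 cannot be read, and the series as a whole offers little room for comparison: the limit of > 100000 nM in this assay, at which 3 of the 4 values shown sit.

As far as these compounds go, whether any group at this position can bring the number down beyond the scatter remains open. An amine or a carboxylic acid on the same aromatic carbon, in place of cyano, would be a direct test of that.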